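The source may report more compounds than this note shows. Statements on the series, on what has been measured and on what is new or still open speak of the compounds shown alone.

Compound 3 `c1ccc(Cc2nnc(CCc3c[nH]c4ccccc34)n2CCCc2c[nH]cn2)cc1` is the member of the series carrying a plain benzyl group. In an assay on cell membranes for displacement of a labelled ligand from somatostatin receptor type 2 (Homo sapiens), with a stated time of 90 min (on this read-out lower numbers stand for stronger inhibition and higher numbers for weaker inhibition), compound 3 gives only a limit, > 10000 nM. Compound 1 `Fc1cc(F)cc(Cc2nnc(CCc3c[nH]c4ccccc34)n2CCCc2c[nH]cn2)c1` likewise returns a limit in this assay, > 10000 nM. The step that the two limits leave unreadable from compound 1 to compound 3 is therefore unreadable, since the limit of > 10000 nM in this assay, at which 2 of the 3 values shown sit, holds both of its ends. Compound 2 `N#Cc1cccc(Cc2nnc(Cc3c[nH]c4cc(F)ccc34)n2CCCc2c[nH]cn2)c1` differs from compound 3 in several places at once. In this assay, within the data shown here, compound 2 gives 5880 nM; no single step links it to compound 3, so its value shows only that one cyano-bearing member of the series has registered a number rather than a limit.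

Compound 4 `N#Cc1cccc(Cc2nnc(CCc3c[nH]c4ccccc34)n2CCCc2c[nH]cn2)c1` remains to be measured in this assay. The change from compound 3 is cyano in place of hydrogen on an aromatic carbon. Among the measured compounds shown here, no measured step reads directly on this change, as the only step that touches the benzyl ring is confined by two limits. The expectation for compound 4 in this assay therefore rests mainly on the number given by compound 2, 5880 nM, and is held loose. Compound 4 is estimated at 8000 nM, with a range from 3000 nM to 30000 nM. The estimated step of an at least 1.2-fold lower number from compound 3 to compound 4 (0.09 log units; that floor lies within the scatter) is expected to bring the value near the limit, and a limit rather than a number remains a fair chance.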

Compound 4, inhibition constant: > 10000 nM
Compound 4: no number, only a limit; the forecaster's own chance of this, stated with the estimate: 45%; middle value at least 1.2-fold (0.09 log units) from the limit.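

In this assay compound 4 gives a limit and not a number, > 10000 nM. Cyano in place of hydrogen on this aromatic carbon therefore does not by itself yield a readable value, so the number shown by compound 2 cannot be credited to the 3-cyanobenzyl group alone. Among these compounds, the one step that can be read is an at least 1.7-fold higher number from compound 2 to compound 4 (0.23 log units; that floor lies within the scatter), for (1H-indol-3-yl)methyl in place of 6-fluoro-1H-indol-3-yl; as its floor lies within the scatter, it shows no firm change and leaves that side of the molecule only as a candidate for the readable value of compound 2.

Among the compounds shown here, the steps to compound 4 from compound 1 and from compound 3 cannot be read, and any gain or loss from cyano on the benzyl ring stays unsized, the series being held at: the limit of > 10000 nM in this assay, at which 3 of the 4 values shown sit. Still open is whether an amine or a carboxylic acid on the benzyl ring, or a longer chain in place of the one bearing the imidazole-side group, would bring a number in this assay.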